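A Remote Aryl Swap and the Acid Dissociation Constant

This account rests on a few compounds, and the source may have more. Where it says the series, first, only, none or still open, it means among the compounds named here.

Measured in a physicochemical assay for acid dissociation:
Compound 1 `COc1cccc(CNCCCNc2ccnc3cc(Cc4cccc(C(F)(F)F)c4)ccc23)c1O` gives 9.47.
Compound 2 `COc1cccc(CNCCCNc2ccnc3cc(Cc4ccc(C#N)cc4)ccc23)c1O` gives 9.47.

Compound 2 stands level with compound 1: the step of no change at the digits printed from compound 1 to compound 2 (within the scatter) shows no change beyond the scatter, although the aryl group on the saturated chain carbon was exchanged. Compound 3 `COc1cccc(CNCCCNc2ccnc3cc(-c4ccc(C(F)(F)F)cc4)ccc23)c1O` differs from compound 2 by 4-(trifluoromethyl)phenyl in place of 4-cyanobenzyl on an aromatic carbon. Among the measured compounds shown here, the one measured step that bears on this is no change at the digits printed from compound 1 to compound 2 (within the scatter), which altered the same outer part of the shared core and left the read-out untouched. The present change goes further, removing the saturated chain carbon and attaching the new ring straight to the aromatic carbon, but it still lies in that same outer region. The expected step is therefore a number 0.02 log units lower from compound 2 to compound 3 (within the scatter), that is none beyond the scatter. Compound 3 is estimated at 9.45, with a range from 9.1 to 9.8.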

Compound 3, acid dissociation constant: 9.47
For compound 3 the middle estimate is 0.02 log units below the measured one; the measured number falls inside the stated range.
By their numbers in this assay, from the lowest: compounds 1, 2 and 3 (each within the scatter of the next).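

Earlier, only the aryl group on the saturated chain carbon had been exchanged; here that carbon is gone and the new ring sits directly on an aromatic carbon, yet this assay shows no change at the digits printed from compound 2 to compound 3 (within the scatter) for this larger change. The comparison that keeps the trifluoromethyl group on both rings, 4-(trifluoromethyl)phenyl in place of 3-(trifluoromethyl)benzyl, agrees, with no change at the digits printed from compound 1 to compound 3 (within the scatter) as its result. So across these three compounds, neither the group on the outer ring nor the presence of the saturated chain carbon shifts this read-out beyond the scatter, and no further data here explain that result.

On these data alone, what remains open is whether a group of another kind on this aromatic carbon, such as an amine, a carboxylic acid or a longer chain, would leave the number in this assay as it stands. The three compounds also share everything else in the core, so they say nothing about changes made elsewhere in it.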